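Branching the ester chain: from compound 3 to compound 4

The source may hold more compounds than are shown below. What is called first, only, known or untested is meant among the compounds shown, and "the series" means these compounds.

Three esters share one core and differ only in the acyl chain. In an ADME assay for solubility, at 25 degrees C (on this read-out lower numbers stand for lower solubility and higher numbers for higher solubility), compound 1 `CC(=O)OCC(CO)OCn1cnc2c(F)nc(N)nc21` gives 44400 ug/mL, compound 2 `CCC(=O)OCC(CO)OCn1cnc2c(F)nc(N)nc21` gives 19000 ug/mL, and compound 3 `CCCC(=O)OCC(CO)OCn1cnc2c(F)nc(N)nc21` gives 19400 ug/mL. Compound 3 stands second highest of the three: its number sits within the scatter of compound 2, and it lies below compound 1 by a margin beyond the scatter. The step of a 2.3-fold lower number from compound 1 to compound 2 (0.37 log units; beyond the scatter) and the step of a 2.3-fold lower number from compound 1 to compound 3 (0.36 log units; beyond the scatter) were both modest drops, while a 1.0-fold higher number from compound 2 to compound 3 (0.01 log units; within the scatter) did not move the number beyond the scatter. Compound 4 `CC(C)C(=O)OCC(CO)OCn1cnc2c(F)nc(N)nc21` differs from compound 3 by isopropyl in place of propyl on a carbonyl carbon. Among the compounds with values here, no measured step involves a branched chain, so the closest guide is a 1.0-fold higher number from compound 2 to compound 3 (0.01 log units; within the scatter), where a methyl in place of hydrogen on the saturated chain changed little. Compound 4 is therefore expected to show no step beyond the scatter in this assay, an estimated 1.0-fold lower number from compound 3 to compound 4 (0.01 log units; within the scatter). Compound 4 is estimated at 19000 ug/mL, with an expected range from 9000 ug/mL to 40000 ug/mL.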

Compound 4, solubility: 57000 ug/mL
The estimate for compound 4 lay 3.0-fold (0.48 log units) below the measured number; measured number above the stated range.
By their numbers in this assay, from the lowest: compounds 2 and 3 (each within the scatter of the next); then compounds 1 and 4 (each within the scatter of the next).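

In this assay the carbonyl carbon proves sensitive to the shape of its chain, not just its size: with the same atoms joined differently, isopropyl in place of propyl gives a 2.9-fold higher number from compound 3 to compound 4 (0.47 log units; beyond the scatter), a step the earlier straight chains did not show. Methyl in place of hydrogen on the saturated chain carbon bound to the carbonyl carbon gives a similar a 3.0-fold higher number from compound 2 to compound 4 (0.48 log units; beyond the scatter), whereas a 1.3-fold higher number from compound 1 to compound 4 (0.11 log units; within the scatter) leaves those two esters level, so a larger acyl group need not go with a lower number. No measurement shown gives a reason for this difference between branched and straight chains.

With a single branched chain shown, it remains open whether tert-butyl or cyclopropyl on the carbonyl carbon would stand with the isopropyl ester or with the straight chains. From the compounds shown here alone, whether branching further out along a longer chain would have any such effect also remains open.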